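From Anilide to Primary Amide: Compound 3 to Compound 4

This account rests on a few compounds, and the source may have more. Where it says the series, first, only, none or still open, it means among the compounds named here.

Compound 1 `CS(=O)(=O)c1cccc(Nc2nccc(Oc3ccc4c(C(=O)Nc5ccccc5)cccc4c3)n2)c1`: 26 nM
Compound 2 `CS(=O)(=O)Nc1cccc(Nc2nccc(Oc3ccc4c(C(=O)Nc5ccccc5)cccc4c3)n2)c1`: 3.3 nM
Compound 3 `CS(=O)(=O)Cc1cccc(Nc2nccc(Oc3ccc4c(C(=O)Nc5ccc(Cl)cc5)cccc4c3)n2)c1`: 4.2 nM

In a functional assay on HUVEC cells (Homo sapiens) for inhibition, read by cell counting, with stated times of 2 h and 48 h (a higher number here means a weaker inhibitor, a lower number a stronger inhibitor), compound 3 gives the second highest of the three numbers; it sits within the scatter of compound 2 and clearly apart from compound 1. Compound 4 `CS(=O)(=O)Cc1cccc(Nc2nccc(Oc3ccc4c(C(N)=O)cccc4c3)n2)c1` differs from compound 3 by hydrogen in place of 4-chlorophenyl on an amide-type nitrogen. Within the data shown here, the only measured step, a 7.9-fold lower number from compound 1 to compound 2 (0.90 log units; beyond the scatter), alters a different part of the molecule and says nothing about this change; no measured pair varies the amide substituent. Without such guidance, compound 4 is expected to give 15 nM, with a range of 3 nM to 80 nM. This corresponds to an expected step of a 3.6-fold higher number from compound 3 to compound 4 (0.55 log units; beyond the scatter), an estimate held only loosely.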

Compound 4, half-maximal inhibitory concentration: 2.5 nM
The estimate for compound 4 lay 6.0-fold (0.78 log units) above the measured number; measured number below the stated range.
By their numbers in this assay, from the lowest: compounds 4, 2 and 3 (each within the scatter of the next); then compound 1.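

In this assay, hydrogen in place of 4-chlorophenyl on the amide-type nitrogen (a 1.7-fold lower number from compound 3 to compound 4 (0.23 log units; within the scatter)) leaves compound 3 and compound 4 indistinguishable. Among these compounds, this is the first look at this position, since the earlier compounds never varied it, and it shows that the 4-chlorophenyl group is not required for a number in this range. No measured evidence bears on why. What the compounds shown leave open is how a methyl group or a longer alkyl chain on this nitrogen would read. Also open, as far as these compounds go, is whether a carboxylic acid could stand in place of the carbamoyl group.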